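Selenium-to-sulfur swap on a quinoline-bearing diacyl isothiourea core

A few compounds are considered here, and "the series" means these few. Any claim that something is new, unique, unknown or untested is made for them only; others in the source may bear on it.

Measured compounds:
- compound 1, `C[Se]/C(=N\C(=O)c1ccco1)NC(=O)c1ccco1`: 40200 nM
- compound 2, `CS/C(=N\C(=O)c1ccco1)NC(=O)c1ccco1`: 46500 nM
- compound 3, `C[Se]/C(=N\C(=O)c1cnc2ccccc2c1)NC(=O)c1cnc2ccccc2c1`: 52100 nM

All three values come from an ADME assay on MCF-10A cells (Homo sapiens) for cytotoxicity, read by MTT assay, with a stated time of 72 h; a higher number here means a weaker inhibitor of growth, a lower number a stronger inhibitor of growth. Compound 1 and compound 2 share a core and differ only by a group of 2 heavy atoms (1 carbon, 1 sulfur; no ring) in place of a group of 2 heavy atoms (1 carbon, 1 selenium; no ring), on a carbon with a double bond to nitrogen; the step of a 1.2-fold higher number from compound 1 to compound 2 (0.06 log units; within the scatter) shows that, on this core, the swap leaves the read-out essentially where it was. Compound 3 carries a different core, and the difference between the core of compound 1 and the core of compound 3 is not broken down here; its value sits close to those of compound 1 and compound 2, within the scatter of both.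

Compound 4, `CS/C(=N\C(=O)c1cnc2ccccc2c1)NC(=O)c1cnc2ccccc2c1`, has not been measured in this assay. It differs from compound 3 by a group of 2 heavy atoms (1 carbon, 1 sulfur; no ring) in place of a group of 2 heavy atoms (1 carbon, 1 selenium; no ring), on a carbon with a double bond to nitrogen, the same change as that from compound 1 to compound 2. Since that earlier step was flat, the expectation is that compound 4 stays near compound 3, giving an estimated step of a 1.1-fold higher number from compound 3 to compound 4 (0.05 log units; within the scatter). Compound 4 is therefore estimated at 58000 nM, with a likely range from 30000 nM to 110000 nM.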

Compound 4, concentration for total growth inhibition: 42200 nM
Compound 4: middle estimate off by 1.4-fold (0.14 log units), on the high side; low and high end bracket the measured number.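

In this assay, methylsulfanyl entering in place of the selenium-bearing group gives a 1.2-fold lower number from compound 3 to compound 4 (0.09 log units; within the scatter), so the step on this second core is also flat. The two steps cannot be told apart, and neither points to a real change in the read-out: the same change on two cores in this assay, a 1.2-fold higher number (0.06 log units; within the scatter) from compound 1 to compound 2 and a 1.2-fold lower number (0.09 log units; within the scatter) from compound 3 to compound 4, 1.4-fold (0.15 log units) apart, within the scatter of two such steps. This shows that the swap carries across these two cores without a detectable effect, but it gives no direction for the change and, resting on two matched pairs, sets no rule for the wider series.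

The compounds shown leave open whether the swap stays flat with a longer chain in place of the methyl on selenium or sulfur, or on a core carrying an amine or a carboxylic acid. They also leave open whether the same flat result would appear in another cell line, since every value here comes from a single cell type.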